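The compounds below may be only part of what the source reports. "The series", "measured", "known", "first", "only" and "open" are said of these compounds alone.

Values in a functional assay on WI-38 cells (Homo sapiens) for cytotoxicity; on this read-out higher numbers stand for weaker inhibition and lower numbers for stronger inhibition:
Compound 1 `O=C1c2ccccc2C(=O)N1c1ccccc1`: > 100 ug/mL
Compound 2 `CCCCCc1ccccc1N1C(=O)c2ccccc2C1=O`: > 100 ug/mL
Compound 3 `CC(C)c1ccccc1N1C(=O)c2ccccc2C1=O`: > 100 ug/mL

Each of these entries is a limit and not a number. Compound 3 stands at a limit, > 100 ug/mL. The series as a whole sits at the limit of > 100 ug/mL in this assay, at which 3 of the 3 values shown sit, so no order among the three compounds can be given.

The next compound is compound 4 `O=C1c2ccccc2C(=O)N1c1ccccc1[N+](=O)[O-]`, with nitro in place of isopropyl on an aromatic carbon, ortho to a large group: nitro in place of isopropyl on an aromatic carbon.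

Within the data shown here, three measured steps bear on this change: a step that the two limits leave unreadable from compound 1 to compound 3, a step that the two limits leave unreadable from compound 1 to compound 2 and a step that the two limits leave unreadable from compound 2 to compound 3. None of them has a readable size, and none of them brings in nitro, so the series gives no direction for this change. No step beyond the scatter is therefore expected in this assay, and a further limit is the likeliest report for compound 4. The expected step is a number no higher from compound 3 to compound 4 (the limit leaves the size open). For compound 4 the estimated value is 100 ug/mL, with an expected range from 40 ug/mL to 250 ug/mL.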

Compound 4, half-maximal inhibitory concentration: > 100 ug/mL
Compound 4: a limit, no number; the forecaster's own chance of this, stated with the estimate: 75%; the middle value lies on the limit itself.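

In this assay compound 4 gives > 100 ug/mL, which is a limit and not a number. Its steps from compound 1, compound 2 and compound 3 therefore cannot be read. All four compounds now stand together: the limit of > 100 ug/mL in this assay, at which 4 of the 4 values shown sit.

The compounds shown leave open how they rank against one another and whether any change on the shared core gives a measurable value in this assay.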